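Replacing cyclopropyl with 4-chlorophenyl: what to expect for compound 3

The source may report more compounds than this note shows. Statements on the series, on what has been measured and on what is new or still open speak of the compounds shown alone.

In a functional assay on A549 cells (Homo sapiens) for antiproliferative activity, read by MTT assay, with a stated time of 72 h (on this read-out lower numbers stand for stronger inhibition and higher numbers for weaker inhibition), the compounds measured so far are:
- compound 1 `COc1ncc(-c2ccc3c(c2)N(c2ccc(F)cc2)C(=O)CO3)cc1NS(=O)(=O)c1ccc(F)cc1` with 6500 nM
- compound 2 `COc1ncc(-c2ccc3c(c2)N(C2CC2)C(=O)CO3)cc1NS(=O)(=O)c1ccc(F)cc1` with 3320 nM

For the measured compounds named here, only one step has been measured, a 2.0-fold lower number from compound 1 to compound 2 (0.29 log units; within the scatter), and it swaps 4-fluorophenyl for cyclopropyl on an amide-type nitrogen in a ring. Going by the values given here, on these numbers, compound 2 sits alongside the only other measured compound rather than clearly ahead of it.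

Compound 3 `COc1ncc(-c2ccc3c(c2)N(c2ccc(Cl)cc2)C(=O)CO3)cc1NS(=O)(=O)c1ccc(F)cc1` has not yet been measured. Its difference from compound 2 is 4-chlorophenyl in place of cyclopropyl on an amide-type nitrogen in a ring. Among the compounds with values here, this runs roughly opposite to the measured step, returning to a substituted phenyl group like the one in compound 1. Within the data shown here, that single small step is the only guide, and no measured compound here carries chlorine. In this assay a slight rise is therefore expected, of similar size and not clearly beyond the scatter. The expected change is a 1.8-fold higher number from compound 2 to compound 3 (0.26 log units; within the scatter) by estimate alone. Compound 3 is estimated at 6000 nM (expected range 2000 nM to 15000 nM).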

Compound 3, half-maximal inhibitory concentration: 8350 nM
Compound 3: the middle estimate sits 1.4-fold (0.14 log units) below what was measured; the measured number falls inside the stated range.
By their numbers in this assay, from the lowest: compounds 2, 1 and 3 (each within the scatter of the next, the first and the last beyond it).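

In this assay, this position on the amide-type nitrogen now shows a separation beyond the usual scatter, though a modest one: a 2.5-fold higher number from compound 2 to compound 3 (0.40 log units; beyond the scatter), so cyclopropyl and 4-chlorophenyl can be told apart here, which the earlier pair of compounds could not show for cyclopropyl and 4-fluorophenyl. The halogen on the phenyl ring makes no readable difference, with a 1.3-fold higher number from compound 1 to compound 3 (0.11 log units; within the scatter), so chloro and fluoro at this spot cannot be separated in this read-out, and the two halogen-bearing phenyl compounds stand level with each other. No supporting measurement is available to explain why the numbers fall as they do.

The compounds shown leave open whether a plain phenyl with no halogen would behave like the two halogen-bearing phenyl groups, and whether a small open chain such as ethyl would match the cyclopropyl of compound 2 at 3320 nM. They also leave open what a longer chain ending in an amine or a carboxylic acid would do on this nitrogen, and whether any group here could bring the number far lower.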